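The source may hold more compounds than are shown below. What is called first, only, known or untested is meant among the compounds shown, and "the series" means these compounds.

Compound 1 `O=C(COc1ccc(Cl)cc1)Nc1nc(-c2ccc(Br)cc2)cs1` and compound 2 `Cc1cc(OCC(=O)Nc2nc(-c3ccc(Br)cc3)cs2)ccc1Cl` share a core, and compound 3 `O=C(COc1ccccc1)Nc1nc(-c2ccc(Cl)cc2)cs1` carries a related core; how the core of compound 3 differs from that of compound 1 is not broken down here. In a functional assay on MCF7 cells (Homo sapiens) for cytotoxicity, read by MTT assay, with a stated time of 48 h (a higher number here means a weaker inhibitor, a lower number a stronger inhibitor), compound 1 gives 41100 nM, compound 2 gives 52100 nM, and compound 3 gives 60300 nM. The three values lie close together. The change methyl in place of hydrogen on an aromatic carbon made the step of a 1.3-fold higher number from compound 1 to compound 2 (0.10 log units; within the scatter), a step too small to count as a real difference.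

Compound 4 `Cc1ccccc1OCC(=O)Nc1nc(-c2ccc(Cl)cc2)cs1` is not yet measured. The change methyl in place of hydrogen on an aromatic carbon is the same kind of change, but the place is not the same: in compound 2 the methyl sits ortho to a chloro group and meta to a large group, whereas in compound 4 it sits ortho to a large group. Because the step of a 1.3-fold higher number from compound 1 to compound 2 (0.10 log units; within the scatter) was small, the step from compound 3 to compound 4 is expected to be small as well, a 1.1-fold higher number from compound 3 to compound 4 (0.04 log units; within the scatter). Compound 4 is therefore estimated to give 66000 nM in this assay, with a likely range from 30000 nM to 145000 nM.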

Compound 4, half-maximal inhibitory concentration: 62200 nM
The estimate for compound 4 lay 1.1-fold (0.03 log units) above the measured number; measured number inside the range.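

In this assay, methyl in place of hydrogen gives a 1.0-fold higher number from compound 3 to compound 4 (0.01 log units; within the scatter), so this step is also too small to count as a real difference. Set side by side, the two steps do not differ: the same change on two cores in this assay, a 1.3-fold higher number (0.10 log units; within the scatter) from compound 1 to compound 2 and a 1.0-fold higher number (0.01 log units; within the scatter) from compound 3 to compound 4, 1.2-fold (0.09 log units) apart, within the scatter of two such steps. On these two cores, then, the change carried over in the sense that it left the number within the scatter both times, even though the methyl does not stand at the same place in the two pairs; this does not show that it would do so on other cores, and two steps this small cannot tell why the number holds still.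

The compounds shown leave open whether any other group at this place on the ring would produce a real difference, for example an amine, a carboxylic acid or a longer chain in place of the methyl. They also leave open whether the 2-methylphenoxy change would stay this small on the core of compound 1.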